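This account rests on a few compounds, and the source may have more. Where it says the series, first, only, none or still open, it means among the compounds named here.

In a functional assay on HCT-116 cells (Homo sapiens) for antiproliferative activity, read by MTT assay, with a stated time of 72 h (a higher number here means a weaker inhibitor, a lower number a stronger inhibitor), compound 1 `COc1ncc(-c2ccc3nc(NC(=O)NCCN(C)C)sc3c2)cc1NS(=O)(=O)c1ccc(F)cc1` gives 240 nM, the second highest of the three numbers here; compound 3 `CCN(CC)CCNC(=O)Nc1nc2ccc(-c3cnc(OC)c(NS(=O)(=O)c4ccc(C)cc4)c3)cc2s1` gives 180 nM, a value within the scatter of compound 1, while compound 2 `COc1ncc(-c2ccc3nc(NC4CC4)sc3c2)cc1NS(=O)(=O)c1ccc(F)cc1` gives 1560 nM. Compound 4 `COc1ncc(-c2ccc3nc(NC(=O)NC4CC4)sc3c2)cc1NS(=O)(=O)c1ccc(F)cc1` differs from compound 1 by cyclopropyl in place of 2-(dimethylamino)ethyl on an amide-type nitrogen. Going by the values given here, the only measured step that bears on this is the larger change a 6.5-fold higher number from compound 1 to compound 2 (0.81 log units; beyond the scatter), in which the whole carbamoyl side chain gave way to cyclopropyl. Compound 4 keeps the urea and changes only the chain, so a smaller shift in the same direction is expected, a 2.5-fold higher number from compound 1 to compound 4 (0.40 log units; beyond the scatter). Compound 4 is therefore estimated at 600 nM, expected to lie between 250 nM and 1500 nM.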

Compound 4, half-maximal inhibitory concentration: 470 nM
Compound 4: the middle estimate sits 1.3-fold (0.11 log units) above what was measured, within the range that was stated.
By their numbers in this assay, from the lowest: compounds 3, 1 and 4 (each within the scatter of the next, the first and the last beyond it); then compound 2.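

In this assay, cyclopropyl in place of 2-(dimethylamino)ethyl on the amide-type nitrogen gives a 2.0-fold higher number from compound 1 to compound 4 (0.29 log units; within the scatter), so at this position the amine-bearing chain can be replaced without a change beyond the scatter. Cyclopropylcarbamoyl in place of cyclopropyl gives a 3.3-fold lower number from compound 2 to compound 4 (0.52 log units; beyond the scatter), which ties a clear part of the gap seen earlier to the carbamoyl unit rather than to the chain. No measurement here explains either step. As far as these compounds go, it remains open how a longer chain, a morpholine or a carboxylic acid on this nitrogen would compare.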